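The compounds below may be only part of what the source reports. "The series", "measured", "known", "first", "only" and "open" are said of these compounds alone.

In a functional assay on RPMI-7951 cells (Homo sapiens) for cytotoxicity (on this read-out lower numbers stand for an effect already at smaller amounts and higher numbers for an effect only at larger amounts of compound), compound 1 `Oc1ccc2nc(-c3ccccc3)cc(O)c2c1` gives 3.92 ug/mL and compound 2 `Oc1ccc2c(O)cc(-c3ccccc3)nc2c1` gives 0.52 ug/mL, so the lower value of this pair belongs to compound 2. Compound 3 `Oc1cc(-c2ccccc2)nc2c(O)cccc12` reads > 10 ug/mL in this assay. That reading is a limit of the assay and not a number, so compound 3 has no exact position on the scale.

Compound 4 `Oc1cc(-c2ccccc2)nc2c(F)cccc12` differs from compound 3 in one place: fluoro in place of hydroxy on an aromatic carbon. It carries fluoro in place of hydroxy on an aromatic carbon, ortho to a fused ring and meta to a fused ring. Within the data shown here, no measured pair shows this exchange, so the expectation for this assay is loose: a modest move toward smaller amounts, or a reading that stays at the limit. The measured reference is compound 1 at 3.92 ug/mL, which shows that a number can be obtained on the shared core. The expected change is an at least 2.0-fold lower number from compound 3 to compound 4 (0.30 log units; that floor lies within the scatter). For compound 4 the estimated value is 5 ug/mL, with an expected range of 1.5 ug/mL to 10 ug/mL.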

Compound 4, half-maximal effective concentration: 0.38 ug/mL
Beside the measured number, compound 4's estimate is 13-fold (1.12 log units) above it; measured number outside the range, below it.
By their numbers in this assay, from the lowest: compounds 4 and 2 (each within the scatter of the next); then compound 1. At a limit, above all of these: compound 3.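

Compound 3 reads > 10 ug/mL in this assay, and that reading is a limit of the assay and not a number. Fluoro in place of hydroxy on this aromatic carbon, ortho to a fused ring and meta to a fused ring, gives an at least 26-fold lower number from compound 3 to compound 4 (1.42 log units; beyond the scatter), so a single exchange at this position is enough to bring the shared core from the limit to a measured number. This step is only a floor and its full size remains unknown, because one end of it rests on a limit: the limit of > 10 ug/mL in this assay, at which 1 of the 4 values shown sits.

The compounds shown do not tell whether the lower number comes from fluoro itself or simply from the departure of hydroxy. Plain hydrogen, chloro or methoxy on the same carbon would separate these two readings.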